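A few compounds are considered here, and "the series" means these few. Any claim that something is new, unique, unknown or untested is made for them only; others in the source may bear on it.

Measured so far in a functional assay on HEK293 cells for agonist activity at growth hormone secretagogue receptor type 1 (Homo sapiens), read by HTRF and inositol phosphate accumulation, with a stated time of 90 min, in the presence of a further agent that is not named here; a lower number here means a smaller maximal response, a higher number a larger maximal response:
compound 1 `Cc1ccc2[nH]c(C(=O)N[C@H]3CN(S(=O)(=O)c4ccccc4)C[C@@H]3C(=O)NCCN(C)C)cc2c1`: 93%
compound 2 `Cc1ccc2[nH]c(C(=O)N[C@H]3CCN(S(=O)(=O)c4ccccc4)C[C@@H]3C(=O)NCCN(C)C)cc2c1`: 98%

In this assay the value of compound 2 and that of compound 1 lie within the usual scatter of each other, so neither stands apart. Compound 3 `Cc1ccc2[nH]c(C(=O)N[C@H]3CCN(C(=O)c4cccnc4)C[C@@H]3C(=O)NCCN(C)C)cc2c1` is not yet measured; it differs from compound 2 in one place: (pyridin-3-yl)carbonyl in place of phenylsulfonyl on an amine nitrogen in a ring. Within the data shown here, no step between measured compounds covers a change of this kind, so the direction is open; a drop beyond the scatter cannot be excluded, and the expected step is a number 13 percentage points lower from compound 2 to compound 3 (beyond the scatter). For compound 3 in this assay the estimate is 85%, with a range from 55% to 105%.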

Compound 3, largest response reached (Emax), in percent of the reference or control that the assay uses: 91%
The estimate for compound 3 lay 6 percentage points below the measured number; low and high end bracket the measured number.
By their numbers in this assay, from the lowest: compounds 3, 1 and 2 (each within the scatter of the next).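

In this assay, (pyridin-3-yl)carbonyl in place of phenylsulfonyl on the amine nitrogen in the ring gives a number 7 percentage points lower from compound 2 to compound 3 (within the scatter). This nitrogen therefore accepts either a sulfonyl or a carbonyl link, and either a carbon-only aromatic ring or one with a hetero atom, with no step beyond the scatter in maximal response. Nothing available here explains this result. Going by these compounds, whether a benzyl group, an acetyl group or the free amine at this nitrogen would give a similar maximal response remains open. So does how potency changes, which a maximal response cannot show.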